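The source may report more compounds than this note shows. Statements on the series, on what has been measured and on what is new or still open speak of the compounds shown alone.

Compound 3, `NS(=O)(=O)Cc1noc2ccc(Cl)cc12`, holds the lowest of the three numbers measured in a functional assay on the whole organism (strain STD-dd) with Mus musculus as the target, in the maximal electroshock model, with a stated time of 2 h; on this read-out higher numbers stand for an effect only at larger amounts of compound and lower numbers for an effect already at smaller amounts: compound 3 gives 14 mg/kg, whereas compound 1, `CNS(=O)(=O)Cc1noc2ccccc12`, gives 23 mg/kg and compound 2, `CNS(=O)(=O)Cc1noc2ccc(F)cc12`, gives 35 mg/kg. The gap from compound 3 to compound 1 is within the scatter, and only the gap to compound 2 lies beyond it, so compound 3 cannot be called the most potent on these data. Compound 4, `CNS(=O)(=O)Cc1noc2ccc(Cl)cc12`, differs from compound 3 by methyl in place of hydrogen on a sulfonamide nitrogen. For the measured compounds named here, no measured pair shows this change on its own: the single measured step, a 1.5-fold higher number from compound 1 to compound 2 (0.18 log units; within the scatter), concerns a different change and stays within the scatter. Compounds 1 and 2 both carry the methylsulfamoyl group of compound 4, and their values in this assay fall in the same band as that of compound 3. Compound 4 is therefore expected to show a step of a 1.3-fold higher number from compound 3 to compound 4 (0.11 log units; within the scatter), not beyond the scatter. The estimate for compound 4 in this assay is 18 mg/kg, with a range from 8 mg/kg to 40 mg/kg.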

Compound 4, dose for half-maximal effect: 20 mg/kg
Beside the measured number, compound 4's estimate is 1.1-fold (0.05 log units) below it; the range from low to high includes it.
By their numbers in this assay, from the lowest: compounds 3, 4, 1 and 2 (each within the scatter of the next, the first and the last beyond it).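

Methyl in place of hydrogen on a sulfonamide nitrogen now has a measured pair of its own: in this assay the change gives a 1.4-fold higher number from compound 3 to compound 4 (0.15 log units; within the scatter) and so leaves no step that can be told from the scatter, at least with chloro on the aromatic carbon. That aromatic carbon also gains two readings with the methylsulfamoyl group in place, chloro in place of fluoro giving a 1.8-fold lower number from compound 2 to compound 4 (0.24 log units; within the scatter) and chloro in place of hydrogen giving a 1.2-fold lower number from compound 1 to compound 4 (0.06 log units; within the scatter) and so leaving hydrogen, fluoro and chloro there unseparated on this read-out. No measurement at hand explains these results.

From the compounds shown here alone, whether an ethyl group or a longer chain on the sulfonamide nitrogen would stay in this band remains open, as does a methoxy group or nitrile on the aromatic carbon. Going by these compounds, the methyl step is read only with chloro present, so its size with hydrogen or fluoro there is also open.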